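Methylating the phenol of compound 2: an untested step

The source may report more compounds than this note shows. Statements on the series, on what has been measured and on what is new or still open speak of the compounds shown alone.

In a functional assay on MDA-MB-468 cells (Homo sapiens) for inhibition, read by sulforhodamine B assay, with a stated time of 48 h, tested at 10 uM (on this read-out lower numbers stand for a stronger effect and higher numbers for a weaker effect at the one concentration tested), compound 1 `O=C(Nc1cccc(-n2cc(-c3ccncc3)c(-c3cc(O)cc(Cl)c3)n2)c1)Nc1ccc(Cl)c(C(F)(F)F)c1` gives 5.22%.
In this assay compound 2 `O=C(Nc1cccc(-n2cc(-c3ccncc3)c(-c3cc(O)cc(Cl)c3)n2)c1)Nc1ccc(Cl)c(Cl)c1` gives -1.88%.

Within the data shown here, compound 2 stands lowest of the two numbers, with compound 1 as its nearest neighbour; the only measured step, a number 7.1 percentage points lower from compound 1 to compound 2 (within the scatter), is within the scatter, so the two compounds read alike in this assay.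

Compound 3 `COc1cc(Cl)cc(-c2nn(-c3cccc(NC(=O)Nc4ccc(Cl)c(Cl)c4)c3)cc2-c2ccncc2)c1` differs from compound 2 by methyl in place of hydrogen on an oxygen on an aromatic ring. Among the measured compounds shown here, no measured step concerns this place: the one step on record, from compound 1 to compound 2, alters the other aryl ring and leaves the hydroxy untouched. There is therefore nothing in the numbers that would point to a change in either direction for compound 3, and the expectation rests on compound 2 alone. The step from compound 2 to compound 3 is expected to be a number 6.9 percentage points higher from compound 2 to compound 3 (within the scatter), that is, none beyond the scatter. Compound 3 is estimated at 5% in this assay, within a range from -10% to 30% that is kept wide for lack of any bearing step.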

Compound 3, a percentage reported as activity, at one concentration (the size of the read-out at that concentration, not a potency): 0.72%
Estimate against measurement, compound 3: 4.3 percentage points above; low and high end bracket the measured number.
By their numbers in this assay, from the lowest: compounds 2, 3 and 1 (each within the scatter of the next).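

In this assay, methyl in place of hydrogen on the oxygen gives a number 2.6 percentage points higher from compound 2 to compound 3 (within the scatter), so hydroxy and methoxy read alike at this place on the shared core. A free hydroxy is therefore not needed here for the effect seen at the one concentration tested, which the change in the other aryl ring between compound 1 and compound 2 could not show. No measurement available here offers an explanation for this result.

From the compounds shown here alone, it remains open whether a longer chain on this oxygen, or an amine or a carboxylic acid in place of the hydroxy, would also read alike. A single concentration also leaves open whether compound 2 and compound 3 would still read alike at lower concentrations.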